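Hexyl in place of cyano on a deoxyuridine core

The compounds below may be only part of what the source reports. "The series", "measured", "known", "first", "only" and "open" are said of these compounds alone.

Measured compounds, with their readings in an ADME assay on L1210/0 cells (Mus musculus) for cytotoxicity, with a stated time of 48 h; a lower number here means a stronger inhibitor, a higher number a weaker inhibitor:
Compound 1 `Nc1nc(Cl)c2nnn([C@H]3CCCC[C@H]3CO)c2n1` gives 95500 nM in this assay.
Compound 2 `COc1ncnc2c1ncn2C[C@@H]1C[C@H](O)c2ccccc21` gives a limit of the assay, > 200000 nM.
Compound 3 `N#Cc1cn([C@H]2C[C@H](O)[C@@H](CO)O2)c(=O)[nH]c1=O` gives a limit of the assay, > 200000 nM.

Compound 3 therefore stands at the edge of what this assay can report: its reading is a limit, not a number. The same is true for compound 2, so that the limit of > 200000 nM in this assay, at which 2 of the 3 values shown sit, marks where most of the set sits. Only compound 1 returns an actual number, and that number points to weak inhibition.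

Compound 4 `CCCCCCc1cn([C@H]2C[C@H](O)[C@@H](CO)O2)c(=O)[nH]c1=O` differs from compound 3 in one place: hexyl in place of cyano on an aromatic carbon. The cyano group goes, a hexyl chain comes in on the same aromatic carbon of the shared core, and the sugar part is untouched.

Going by the values given here, no step between two measured compounds is available to calibrate this change, and compound 3 itself offers only a limit. The expectation is that the step of an at least 1.3-fold lower number from compound 3 to compound 4 (0.12 log units; that floor lies within the scatter) brings compound 4 to a measurable but still weak reading, rather than leaving it at the limit, though a limit remains quite possible. Compound 4 is thus expected to give about 150000 nM in this assay. For compound 4 the expected range is estimated to run from 30000 nM to 500000 nM.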

Compound 4, half-maximal inhibitory concentration: > 200000 nM
Compound 4 was reported as a limit; the forecaster's own chance of this, stated with the estimate: 50%; middle value at least 1.3-fold (0.12 log units) away from the limit.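

Compound 3 and compound 4 both stop at a limit of the assay rather than at a number, so no step can be read between them. The compounds shown leave open whether hexyl in place of cyano on an aromatic carbon changes the reading in this assay at all, and most of the set rests at one edge: the limit of > 200000 nM in this assay, at which 3 of the 4 values shown sit.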